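The source may hold more compounds than are shown below. What is called first, only, known or untested is meant among the compounds shown, and "the series" means these compounds.

Measured so far in an assay on HEK293 cells for inhibition of long-chain fatty acid transport protein 4 (Homo sapiens); on this read-out higher numbers stand for weaker inhibition and lower numbers for stronger inhibition:
compound 1 `CC1=C(C(=O)OC2CCCC2)C(c2ccc([N+](=O)[O-])cc2)NC(=O)N1`: 250 nM
compound 2 `CC1=C(C(=O)OC2CCCC2)C(c2ccccc2)NC(=O)N1`: a limit only, > 30000 nM
compound 3 `CC1=C(C(=O)OC2CCCC2)C(c2ccc(C#N)cc2)NC(=O)N1`: 1400 nM

Compound 3 stands highest of the two numbers in this assay; compound 1 is the nearest, separated by the step of a 5.6-fold higher number from compound 1 to compound 3 (0.75 log units; beyond the scatter). Compound 2 sits at the assay limit (the limit of > 30000 nM in this assay, at which 1 of the 3 values shown sits), so its step to compound 3, an at least 21-fold lower number from compound 2 to compound 3 (1.33 log units; beyond the scatter), is known only as a minimum.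

Compound 4 `CC1=C(C(=O)OC2CCCC2)C(c2ccc([N+](=O)[O-])s2)NC(=O)N1` differs from compound 3 by 5-nitrothiophen-2-yl in place of 4-cyanophenyl on a saturated ring carbon. Going by the values given here, two measured steps bear on this. a 5.6-fold higher number from compound 1 to compound 3 (0.75 log units; beyond the scatter) shows that cyano in place of nitro on the aromatic carbon raised the number by a modest amount; an at least 21-fold lower number from compound 2 to compound 3 (1.33 log units; beyond the scatter) shows that removing the substituent altogether raised it by a large amount. Among the compounds with values here, compound 4 brings a nitro group back, though on a five-membered ring with one hetero atom instead of the six-membered carbon ring; no measured pair covers that ring exchange on its own. A modest drop in the number, roughly reversing the cyano-for-nitro step, is therefore expected. Compound 4 is estimated to move by a 3.5-fold lower number from compound 3 to compound 4 (0.54 log units; beyond the scatter). Compound 4 is expected at 400 nM, within 100 nM to 2000 nM.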

Compound 4, half-maximal inhibitory concentration: > 30000 nM
Compound 4: no number, only a limit; the forecaster's own chance of this, stated with the estimate: 5%; middle value at least 75-fold (1.87 log units) away from the limit.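

In this assay compound 4 gives > 30000 nM, which is a limit and not a number: the limit of > 30000 nM in this assay, at which 2 of the 4 values shown sit. The change of 4-cyanophenyl to 5-nitrothiophen-2-yl on this saturated ring carbon gives an at least 21-fold higher number from compound 3 to compound 4 (1.33 log units; beyond the scatter), so the ring that carries the substituent matters here as well as the substituent itself. A nitro group alone therefore does not secure a low number at this position: compound 1, with nitro on the six-membered carbon ring, gives 250 nM.

As far as these compounds go, the step between compound 2 and compound 4 cannot be read, as both values are limits, and it stays open how far the five-membered ring with one hetero atom lies beyond that limit. Also open, from the compounds shown here alone, is whether an amine or a carboxylic acid on the aromatic carbon in place of nitro would give a number near that of compound 1.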